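The compounds below may be only part of what the source reports. "The series", "measured", "known", "first", "only" and "open" are said of these compounds alone.

Working notes on the series.

Within the data shown here, compound 1 `CC(C)(C)c1cc(NC(=O)Nc2ccc(Cl)cc2)n(-c2ccc(C#N)cc2)n1` carries a cyano group on the aromatic ring attached to the pyrazole-type nitrogen of the shared core; in an assay on isolated protein for inhibition of Ephrin type-A receptor 2 (Homo sapiens), read by thermal shift assay, tested at 10 uM (on this read-out lower numbers stand for weaker stabilisation of the target and higher numbers for stronger stabilisation of the target against heat), compound 1 gives 0.8 degrees C. Compound 2 `CC(C)C(=O)Nc1ccc(-n2nc(C(C)(C)C)cc2NC(=O)Nc2ccc(Cl)cc2)cc1` differs from compound 1 only in that an (isopropylcarbonyl)amino group replaces the cyano; in this assay compound 2 gives 2.8 degrees C. The step of a number 2.0 degrees C higher from compound 1 to compound 2 (beyond the scatter) is the single measured change so far, and it places compound 2 at the top of the two numbers measured, with compound 1 the nearer and only neighbour.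

Compound 3 `CC(C)(C)c1cc(NC(=O)Nc2ccc(Cl)cc2)n(-c2ccc(NS(C)(=O)=O)cc2)n1` is the next point. The change from compound 2 is methylsulfonyl in place of isopropylcarbonyl on a nitrogen on an aromatic ring; read one bond further out, it is (isopropylcarbonyl)amino to methanesulfonamido. Among the measured compounds shown here, no measured step touches this exchange directly. For the measured compounds named here, the only step that bears on it at all is a number 2.0 degrees C higher from compound 1 to compound 2 (beyond the scatter), which shows that replacing the cyano with a substituted amino group raised the shift; compound 3 keeps such an amino group, so the same side of that step seems the relevant reference, and the expectation in this assay is a step of about a number 0.50 degrees C lower from compound 2 to compound 3 (within the scatter), within or near the scatter, with no clear direction. Compound 3 is therefore estimated at 2.3 degrees C, with a range from 0.8 degrees C to 3.8 degrees C.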

Compound 3, shift of the target's melting temperature: 2.8 degrees C
For compound 3 the middle estimate is 0.50 degrees C below the measured one; the range from low to high includes it.
By their numbers in this assay, from the lowest: compound 1; then compounds 2 and 3 (each within the scatter of the next).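

In this assay, the exchange of isopropylcarbonyl for methylsulfonyl on a nitrogen on an aromatic ring gives no change at the digits printed from compound 2 to compound 3 (within the scatter), so this assay does not separate the carbonyl-bearing group from the sulfonyl-bearing group at this place. The step of a number 2.0 degrees C higher from compound 1 to compound 3 (beyond the scatter) stands alongside the earlier step of a number 2.0 degrees C higher from compound 1 to compound 2 (beyond the scatter), which shows that among the compounds shown, the higher number relative to the nitrile of compound 1 is not confined to the (isopropylcarbonyl)amino group but is shared by the methanesulfonamido group. No measurement at hand gives a reason for these steps or for the lack of separation between compound 2 and compound 3.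

The compounds shown leave open whether the nitrogen alone, as a free amine, would match the two substituted groups, or whether a group on that nitrogen is needed. They also leave open how far the group on the nitrogen can be extended, for example with a longer chain on the sulfonyl or with a carboxylic acid at its end, before the number in this assay changes beyond the scatter.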